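The source may report more compounds than this note shows. Statements on the series, on what has been measured and on what is new or still open speak of the compounds shown alone.

Measured compounds:
Compound 1 `C#CCSc1nc(Nc2cccc(Cl)c2)c2ccncc2n1` — 56500 nM
Compound 2 `C#CCSc1nc(Nc2cccc(OC)c2)c2ccncc2n1` — 17100 nM

Among the measured compounds shown here, in a functional assay on PC-3 cells (Homo sapiens) for inhibition, read by MTT assay, with a stated time of 72 h (a higher number here means a weaker inhibitor, a lower number a stronger inhibitor), compound 2 holds the lower of the two numbers, the one measured step being a 3.3-fold lower number from compound 1 to compound 2 (0.52 log units; beyond the scatter). Compound 3 `C/C=C/Sc1nc(Nc2cccc(OC)c2)c2ccncc2n1` differs from compound 2 by prop-1-en-1-yl in place of propargyl on a sulfur. For the measured compounds named here, that step concerns only the aromatic substituent and says nothing about the sulfur chain, so no measured step bears on the change to compound 3. Compound 3 is therefore expected to show a 1.0-fold lower number from compound 2 to compound 3 (0.00 log units; within the scatter), nothing beyond the scatter. The estimate for compound 3 is 17000 nM, between 5000 nM and 60000 nM.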

Compound 3, half-maximal inhibitory concentration: 6790 nM
Compound 3: the middle estimate sits 2.5-fold (0.40 log units) above what was measured; the measured number falls inside the stated range.
By their numbers in this assay, from the lowest: compound 3; then compound 2; then compound 1.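

The sulfur chain proves to be a position that moves the result in this assay, which the earlier step, confined to the aromatic substituent, could not show. With the chain's three carbons kept, a double bond in place of the triple bond gives a 2.5-fold lower number from compound 2 to compound 3 (0.40 log units; beyond the scatter), a modest step beyond the scatter. Nothing available explains this step. Still open, as far as these compounds go, is how a longer chain, or an amine at the end of the chain, would read on this sulfur. Also open, from the compounds shown here alone, is whether the step from chloro to methoxy would keep its size with prop-1-en-1-yl on the sulfur.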